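Swapping fluoro for acetyl on the pendant aryl ring

The source may report more compounds than this note shows. Statements on the series, on what has been measured and on what is new or still open speak of the compounds shown alone.

Measured so far in a functional assay on MCF7 cells (Homo sapiens) for inhibition, read by CCK-8 assay, with a stated time of 48 h; on this read-out lower numbers stand for stronger inhibition and higher numbers for weaker inhibition:
- compound 1, `COc1cc(-c2ccnc3cc(-c4ccc(F)cc4)nn23)cc(OC)c1OC`, 1280 nM
- compound 2, `COc1cc(-c2ccnc3cc(-c4ccc(Cl)cc4)nn23)cc(OC)c1OC`, 2320 nM
- compound 3, `COc1cc(-c2ccnc3cc(-c4cccc(C#N)c4)nn23)cc(OC)c1OC`, > 10000 nM

Compound 1 gives the lowest of the two numbers that are not limits; compound 2 sits close to it, since a 1.8-fold higher number from compound 1 to compound 2 (0.26 log units; within the scatter). For compound 3 the value is a limit of the assay rather than a number (the limit of > 10000 nM in this assay, at which 1 of the 3 values shown sits), so an at least 7.8-fold higher number from compound 1 to compound 3 (0.89 log units; beyond the scatter) and an at least 4.3-fold higher number from compound 2 to compound 3 (0.63 log units; beyond the scatter) can only be read as at least that large.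

Compound 4, `COc1cc(-c2ccnc3cc(-c4ccc(C(C)=O)cc4)nn23)cc(OC)c1OC`, differs from compound 1 in one place: acetyl in place of fluoro on an aromatic carbon. Within the data shown here, no measured step exchanges a small halogen for a group like acetyl, so the bearing of the known steps is indirect. The small swap from compound 1 to compound 2 changed little, while the larger rearrangement toward compound 3 pushed the number past the limit. Acetyl is a bigger change than chloro, so a weakening step in this assay is expected, though smaller than the one to compound 3. Compound 4 is therefore estimated at 4000 nM, between 1500 nM and 15000 nM, which would mean an expected 3.1-fold higher number from compound 1 to compound 4 (0.49 log units; beyond the scatter).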

Compound 4, half-maximal inhibitory concentration: 5230 nM
Beside the measured number, compound 4's estimate is 1.3-fold (0.12 log units) below it; measured number inside the range.
By their numbers in this assay, from the lowest: compounds 1 and 2 (each within the scatter of the next); then compound 4. At a limit, above all of these: compound 3.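

In this assay, the place held by fluoro in compound 1 takes an acetyl group and still gives a real number, with a 4.1-fold higher number from compound 1 to compound 4 (0.61 log units; beyond the scatter). Acetyl in place of chloro gives a 2.3-fold higher number from compound 2 to compound 4 (0.35 log units; beyond the scatter). The earlier exchange of fluoro for chloro stayed within the scatter, so compound 4 is the first sign among these compounds that a change at this place on the 4-substituted phenyl ring can move the number beyond it. Compound 3 stands at a limit of the assay: the limit of > 10000 nM in this assay, at which 1 of the 4 values shown sits. That limit leaves only a floor for the size of the step, with an at least 1.9-fold lower number from compound 3 to compound 4 (0.28 log units; that floor lies within the scatter).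

The compounds shown cannot tell whether the carbonyl of acetyl or simply its extra heavy atoms set the size of this step. Going by these compounds, how an amine, a carboxylic acid or a longer chain would read at this place stays open.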